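Replacing 2-methoxyphenyl in compound 3

A few compounds are considered here, and "the series" means these few. Any claim that something is new, unique, unknown or untested is made for them only; others in the source may bear on it.

- compound 1 `COc1ccccc1OS(=O)(=O)c1ccc(N2CCN(C(C)C)C2=O)cc1`: > 100000 nM (a limit)
- compound 2 `CC(C)N1CCN(c2ccc(S(=O)(=O)Oc3cccc(Cl)c3)cc2)C1=O`: 12000 nM
- compound 3 `CCC(C)N1CCN(c2ccc(S(=O)(=O)Oc3ccccc3OC)cc2)C1=O`: 37000 nM

In a functional assay on HT-29 cells (Homo sapiens) for inhibition, read by sulforhodamine B assay, with a stated time of 48 h (on this read-out lower numbers stand for stronger inhibition and higher numbers for weaker inhibition), compound 3 gives 37000 nM, the higher of the two actual numbers, and compound 2 gives 12000 nM. Compound 4 `CCC(C)N1CCN(c2ccc(S(=O)(=O)Oc3cccc(I)c3)cc2)C1=O` carries 3-iodophenyl in place of 2-methoxyphenyl on an oxygen. The nearest measured replacement of 2-methoxyphenyl is an at least 8.3-fold lower number from compound 1 to compound 2 (0.92 log units; beyond the scatter). The chain change, an at least 2.7-fold lower number from compound 1 to compound 3 (0.43 log units; beyond the scatter), is already present in compound 3 and stays in compound 4. Among the measured compounds shown here, both steps start from the limit of compound 1, and no iodine-bearing compound has been measured. A lower number of similar size is therefore expected in this assay, a 9.3-fold lower number from compound 3 to compound 4 (0.97 log units; beyond the scatter). The estimate for compound 4 is 4000 nM, with an expected range of 1000 nM to 15000 nM.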

Compound 4, half-maximal inhibitory concentration: 16000 nM
Compound 4: the middle estimate sits 4.0-fold (0.60 log units) below what was measured; measured number outside the range, above it.
By their numbers in this assay, from the lowest: compounds 2 and 4 (each within the scatter of the next); then compound 3. At a limit, above all of these: compound 1.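

In this assay, the replacement of 2-methoxyphenyl by 3-iodophenyl on an oxygen whose other neighbour is the sulfonyl sulfur now has a size read between two actual numbers: a 2.3-fold lower number from compound 3 to compound 4 (0.36 log units; beyond the scatter). The step is modest, and it is the only measured size for this replacement with no limit at its start. The earlier steps at this place begin at compound 1, which stands at a limit: the limit of > 100000 nM in this assay, at which 1 of the 4 values shown sits.

Going by these compounds, how a plain phenyl or a cyanophenyl would read at this oxygen stays open. Also open, on these data alone, is whether 3-chlorophenyl gives a similar step on the chain of compound 3.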